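Phenyl for Fluoro: Expecting Compound 3 at the Limit

The source may hold more compounds than are shown below. What is called first, only, known or untested is meant among the compounds shown, and "the series" means these compounds.

All numbers come from an in vitro functional assay on HEK285-7 cells for antagonist activity at prostaglandin D2 receptor 2 (Homo sapiens), read by BRET and beta-arrestin recruitment; a higher number here means a larger maximal response, a lower number a smaller maximal response.
Compound 1, `O=C(O)Cc1sc(Nc2ccccc2)nc1-c1ccc(F)cc1`, gives > 70%.
Compound 2, `O=C(O)Cc1sc(-c2ccccc2)nc1-c1ccc(F)cc1`, gives > 70%.
Compound 3, `O=C(O)Cc1sc(-c2ccccc2)nc1-c1ccc(-c2ccccc2)cc1`, is not yet measured.

Compound 2 stands at a limit of this assay, not at a number. The same holds for compound 1, so the step that the two limits leave unreadable from compound 1 to compound 2 cannot be read in size or direction. Going by the values given here, the only thing the two measurements show is the limit of > 70% in this assay, at which 2 of the 2 values shown sit.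

Compound 3 differs from compound 2 by a single change: phenyl in place of fluoro on an aromatic carbon. Among the compounds with values here, no measured step touches this position, and the one step available, from compound 1 to compound 2, is unreadable because both its ends are limits. There is therefore nothing in the data that would push the expectation for compound 3 away from where compound 2 stands.

Compound 3 is thus expected to reach the same limit in this assay, estimated at 85%, between 70% and 100%. The step that the limit leaves unreadable from compound 2 to compound 3 is expected to stay within the scatter.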

Compound 3, largest response reached (reported as efficacy), in percent of the reference or control that the assay uses: > 70%
Compound 3: only a limit was reported; the forecaster's own chance of this, stated with the estimate: 70%; the middle value is on the limit's open side.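

In this assay compound 3 gives > 70% and this is a limit, not a number. Compound 2 also stands at a limit, so no step can be read between compound 2 and compound 3. The compounds shown leave open how far compound 1, compound 2 and compound 3 differ in maximal response, if at all: the limit of > 70% in this assay, at which 3 of the 3 values shown sit.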